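Permeability in a Sulfonamide Series: Estimating Compound 4

This account rests on a few compounds, and the source may have more. Where it says the series, first, only, none or still open, it means among the compounds named here.

Measured compounds in an ADME assay on Caco-2 cells (Homo sapiens) for permeability, in the apical to basolateral direction; a higher number here means that the compound crosses the layer faster, a lower number that the compound crosses the layer more slowly:
compound 1, `Cn1cncc1CN1CC(N(CC2CCN(C(=O)CNC(=O)OC(C)(C)C)CC2)S(=O)(=O)c2ccccn2)Cc2cc(C#N)ccc21`, gives 0.5 10^-6 cm/s
compound 2, `CCCC(=O)N1CCC(CN(C2Cc3cc(C#N)ccc3N(Cc3cncn3C)C2)S(=O)(=O)c2ccccn2)CC1`, gives 0.5 10^-6 cm/s
compound 3, `Cn1cncc1CN1CC(N(CC2CCN(C(=O)N3CCCCC3)CC2)S(=O)(=O)c2ccccn2)Cc2cc(C#N)ccc21`, gives 0.6 10^-6 cm/s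

For the measured compounds named here, compound 2 stands level with compound 1 at the digits printed, the two together giving the lowest of the three numbers; the only other number, that of compound 3, lies within the scatter of it. All three measured steps concern the group on the carbonyl carbon of the shared core: no change at the digits printed from compound 1 to compound 2 (within the scatter), a 1.2-fold higher number from compound 1 to compound 3 (0.08 log units; within the scatter) and a 1.2-fold higher number from compound 2 to compound 3 (0.08 log units; within the scatter), each within the scatter.

Compound 4, `Cn1cncc1CN1CC(N(CC2CCN(S(=O)(=O)c3ccccc3)CC2)S(=O)(=O)c2ccccn2)Cc2cc(C#N)ccc21`, differs from compound 2 as follows: phenylsulfonyl in place of propylcarbonyl on an amine nitrogen in a ring. Going by the values given here, no measured step replaces the carbonyl group itself, so the closest guide is that the three variations around this position left this assay unchanged within the scatter. On that basis no step beyond the scatter is expected, a 1.2-fold higher number from compound 2 to compound 4 (0.08 log units; within the scatter), with a somewhat wider range to allow for the group type not yet examined. Compound 4 is therefore estimated at 0.6 10^-6 cm/s, with a range from 0.25 10^-6 cm/s to 1.5 10^-6 cm/s.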

Compound 4, apparent permeability: 0.1 10^-6 cm/s
Estimate against measurement, compound 4: 6.0-fold (0.78 log units) above; measured number outside the range, below it.
By their numbers in this assay, from the lowest: compound 4; then compounds 1, 2 and 3 (each within the scatter of the next).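

In this assay, the groups borne through a carbonyl on the amine nitrogen in a ring stood within the scatter of one another, yet phenylsulfonyl at that nitrogen gives a 5.0-fold lower number from compound 2 to compound 4 (0.70 log units; beyond the scatter) and a 5.0-fold lower number from compound 1 to compound 4 (0.70 log units; beyond the scatter) and also a 6.0-fold lower number from compound 3 to compound 4 (0.78 log units; beyond the scatter) with each step beyond the scatter. This position is therefore not indifferent in this assay, and compound 4 alone stands apart from the three carbonyl compounds. No measurement shown here gives a reason for this step.

The change replaces the carbonyl with a sulfonyl and also brings in a six-membered aromatic ring of carbon only, and the compounds shown cannot separate these two parts. From the compounds shown here alone, a benzoyl group or a propylsulfonyl group on this nitrogen would bear on that question, and how either would read in this assay remains open.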